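The source may hold more compounds than are shown below. What is called first, only, known or untested is meant among the compounds shown, and "the series" means these compounds.

Compound 1, `OC[C@H]1OC(n2cnc3c(SCc4ccccc4)nccc32)[C@H](O)[C@@H]1O`, in a functional assay (Homo sapiens) for inhibition of Nucleic Acid, tested at 100 uM; on this read-out higher numbers stand for more inhibition at the one concentration tested (going by the name of the read-out) and lower numbers for less inhibition: 30%
Compound 2, `OC[C@H]1OC(n2cnc3c(Nc4ccccc4)nccc32)[C@H](O)[C@@H]1O`, in this assay: 4%
Compound 3, `OCCNc1nccc2c1ncn2C1O[C@H](CO)[C@@H](O)[C@H]1O`, in this assay: 0%

Compound 3 stands lowest of the three numbers in this assay; its nearest neighbour is compound 2, and that gap is within the scatter, while compound 1 lies well beyond it. Compound 4, `CSc1nccc2c1ncn2C1O[C@H](CO)[C@@H](O)[C@H]1O`, is not yet measured. It differs from compound 3 in one place: methylsulfanyl in place of (2-hydroxyethyl)amino on an aromatic carbon. Among the compounds with values here, two measured steps bear on this change. The step of a number 30 percentage points lower from compound 1 to compound 3 (beyond the scatter) shows that exchanging benzylsulfanyl for (2-hydroxyethyl)amino removed all of the inhibition seen for compound 1, and compound 4 takes that direction back in part, since a sulfanyl group returns. But the step of a number 26 percentage points lower from compound 1 to compound 2 (beyond the scatter) shows that anilino also lost most of that inhibition, and no measured compound carries methylsulfanyl, so whether a sulfanyl group without the benzyl portion regains anything cannot be read from these numbers. The step of a number 4 percentage points lower from compound 2 to compound 3 (within the scatter) is within the scatter. A modest rise is therefore expected, smaller than a full return to the number of compound 1. Compound 4 is expected to give 12% in this assay, in the range 0% to 35%. The expected step is a number 12 percentage points higher from compound 3 to compound 4 (beyond the scatter).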

Compound 4, a percentage reported as inhibition, at one concentration (the size of the read-out at that concentration, not a potency): 24%
Compound 4: the middle estimate sits 12 percentage points below what was measured; the range from low to high includes it.
By their numbers in this assay, from the lowest: compounds 3 and 2 (each within the scatter of the next); then compounds 4 and 1 (each within the scatter of the next).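

On this aromatic carbon, next to the ring nitrogen, methylsulfanyl carries inhibition in this assay that neither nitrogen-linked group shows: replacing (2-hydroxyethyl)amino gives a number 24 percentage points higher from compound 3 to compound 4 (beyond the scatter), and replacing anilino gives a number 20 percentage points higher from compound 2 to compound 4 (beyond the scatter). Trimming benzylsulfanyl to methylsulfanyl, with hydrogen in place of phenyl on the chain carbon bound to the sulfur, gives a number 6 percentage points lower from compound 1 to compound 4 (within the scatter), so the phenyl is not needed for the inhibition seen at this one concentration. Across the shared core, compound 1 and compound 4, with sulfur on this carbon, stand apart from compound 2 and compound 3, with nitrogen there, and no compound shown goes against this split. Nothing available explains why the sulfur-linked groups differ from the nitrogen-linked ones.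

On these data alone, whether sulfur itself is what counts remains open, since methoxy or methylamino on the same carbon would separate the linking atom from the small size of the group. Also open, as far as these compounds go, is how a longer chain on the sulfur, such as ethylsulfanyl or propylsulfanyl, would compare, and whether any of these groups reaches beyond the modest inhibition seen so far.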